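The compounds below may be only part of what the source reports. "The series", "measured", "known", "first", "only" and "open" are said of these compounds alone.

Measured so far:
compound 1, `C=CC(=O)NCC#Cc1ccc2ncn(-c3ccnc(N)n3)c2c1`: 6310 nM
compound 2, `C=CC(=O)NCCCc1ccc2ncn(-c3ccnc(N)n3)c2c1`: 501000 nM

Both numbers come from an assay on Sf9 cells for inhibition of mitogen-activated protein kinase kinase kinase 14 variant S549D (Homo sapiens), with a stated time of 30 min, in the presence of a further agent that is not named here; a lower number here means a stronger inhibitor, a higher number a weaker inhibitor. Within the data shown here, on these two numbers compound 1 stands lowest; its only neighbour is compound 2, reached by a 79-fold higher number from compound 1 to compound 2 (1.90 log units; beyond the scatter), a step that swaps the triple-bonded linker for a saturated chain while keeping the amide end.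

Compound 3 is `C#Cc1cc(C#Cc2ccc3ncn(-c4ccnc(N)n4)c3c2)ccn1`, not yet measured in this assay. Relative to compound 1 the change is a group of 8 heavy atoms (7 carbon, 1 nitrogen; one six-membered aromatic ring with 1 hetero atom) in place of a group of 6 heavy atoms (4 carbon, 1 nitrogen, 1 oxygen; no ring), on a triple-bonded carbon. The triple-bonded linker of compound 1 is kept here; what changes is the group on its far end.

Among the measured compounds shown here, the one measured step, from compound 1 to compound 2, touches the linker and not the terminal group, so it bears only indirectly on this change: it shows that the measured number is sensitive to what hangs off the core at this position, and that the sensitivity is large. Nothing measured speaks to removing the amide end while keeping the triple bond. The expectation for compound 3 is therefore a weaker number than compound 1, with a wide range: the estimated step is a 3.2-fold higher number from compound 1 to compound 3 (0.50 log units; beyond the scatter).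

Compound 3 is expected to give 20000 nM, in the range 2500 nM to 160000 nM.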

Compound 3, half-maximal inhibitory concentration: 31600 nM
Compound 3: middle estimate off by 1.6-fold (0.20 log units), on the low side, and the stated range covers the measured number.
By their numbers in this assay, from the lowest: compound 1; then compound 3; then compound 2.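

In this assay, the ((vinylcarbonyl)amino)methyl group on the triple-bonded carbon can be replaced outright by a group with a six-membered aromatic ring, with a 5.0-fold higher number from compound 1 to compound 3 (0.70 log units; beyond the scatter) as the result. That change removes the amide end, its hydrogen-bond donor and both double bonds outside aromatic rings, yet compound 3 still gives a measured number of 31600 nM in this assay, so the amide end is not needed for a finite reading. The step for changing the far-end group is smaller than a 79-fold higher number from compound 1 to compound 2 (1.90 log units; beyond the scatter), the step for saturating the linker with the amide end kept, which gives a first sign that in these three compounds the number responds more to the linker than to this terminal exchange. No evidence is available on what lies behind the step.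

Still open, as far as these compounds go, is which part of the change carries the step: the loss of the ((vinylcarbonyl)amino)methyl group or the arrival of the ring with its own triple bond. A primary amine or a carboxylic acid on the same triple-bonded carbon, or a longer chain ending in the same amide, would help separate these two parts.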